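Working notes: chloro position on the aryl group of compound 3

The source may report more compounds than this note shows. Statements on the series, on what has been measured and on what is new or still open speak of the compounds shown alone.

The series is followed in a functional assay on 786-0 cells (Homo sapiens) for inhibition, read by sulforhodamine B assay, with a stated time of 48 h; a lower number here means a stronger inhibitor of growth, a higher number a weaker inhibitor of growth. Compound 1 `CC1=CC[C@H](C(C)(C)NC(=S)N/N=C/c2ccccc2)CC1` gives 67000 nM in this assay. Compound 2 `COc1ccc(/C=N/NC(=S)NC(C)(C)[C@H]2CC=C(C)CC2)cc1` gives 29600 nM in this assay, and the step is a 2.3-fold lower number from compound 1 to compound 2 (0.35 log units; beyond the scatter). Compound 3 `CC1=CC[C@H](C(C)(C)NC(=S)N/N=C/c2ccccc2Cl)CC1` sits at the limit of > 100000 nM in this assay, at which 1 of the 3 values shown sits, so its result is a limit and not a number. In this assay compound 3 reads > 100000 nM. The step from compound 1 is an at least 1.4-fold higher number from compound 1 to compound 3 (0.17 log units; that floor lies within the scatter), and the step from compound 2 is an at least 3.3-fold higher number from compound 2 to compound 3 (0.52 log units; beyond the scatter); on the numbers shown compound 3 is at the weak end of the three, though only the step from compound 2 is beyond the scatter.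

Compound 4 `CC1=CC[C@H](C(C)(C)NC(=S)N/N=C/c2ccc(Cl)cc2)CC1` differs from compound 3 in one place: 4-chlorophenyl in place of 2-chlorophenyl on a carbon with a double bond to nitrogen. Among the measured compounds shown here, no measured step moves a chloro group alone, so the bearing is indirect. For the measured compounds named here, the only change that lowered the number was a group added at the same position of the ring as in compound 4, with a 2.3-fold lower number from compound 1 to compound 2 (0.35 log units; beyond the scatter), whereas the chloro group at the other position in compound 3 gave an at least 1.4-fold higher number from compound 1 to compound 3 (0.17 log units; that floor lies within the scatter). The expectation is therefore a step of an at least 1.6-fold lower number from compound 3 to compound 4 (0.22 log units; that floor lies within the scatter), back toward the range of compound 1. Compound 4 is estimated at 60000 nM, between 25000 nM and 150000 nM.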

Compound 4, concentration for total growth inhibition: > 100000 nM
Compound 4: a limit, no number (the forecaster's own chance of this, stated with the estimate: 35%); middle value at least 1.6-fold (0.22 log units) away from the limit.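

Working notes: what compound 4 adds

Replacing 2-chlorophenyl with 4-chlorophenyl on the carbon with a double bond to nitrogen gives compound 4 a limit and not a number in this assay, as for compound 3: the limit of > 100000 nM in this assay, at which 2 of the 4 values shown sit. Chloro in place of methoxy gives an at least 3.3-fold higher number from compound 2 to compound 4 (0.52 log units; beyond the scatter), so the lower number of compound 2 does not carry over to the chloro group in 4-chlorophenyl, while chloro in place of hydrogen gives an at least 1.4-fold higher number from compound 1 to compound 4 (0.17 log units; that floor lies within the scatter), a floor that does not separate compound 4 from compound 1. The two limits leave the step between compound 3 and compound 4 unreadable, so neither chlorophenyl group can be ranked over the other in this assay.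

From the compounds shown here alone, how far compound 3 and compound 4 lie beyond the limit remains unknown, and so does any real difference between them. Going by these compounds, with only methoxy giving a lower number than hydrogen, it also remains open whether a hydroxyl or an amine in place of the methoxy of compound 2 would keep that lower number.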